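Moving the Methoxy Group Around the Biaryl Ring

This account rests on a few compounds, and the source may have more. Where it says the series, first, only, none or still open, it means among the compounds named here.

Measured compounds:
compound 1 `COc1ccccc1-c1ccc(CNC(=O)NC2CCN(Cc3ccc(C)cc3)CC2)cc1` — 6.19
compound 2 `Cc1ccc(CN2CCC(NC(=O)N(CC(=O)C(C)(C)O)Cc3ccc(-c4ccc(F)cc4)cc3)CC2)cc1` — 5.34
compound 3 `COc1ccc(-c2ccc(CN(CC(=O)C(C)(C)O)C(=O)NC3CCN(Cc4ccc(C)cc4)CC3)cc2)cc1` — < 5

Of the compounds shown here, three have been measured in an in vitro functional assay on HEK293 cells for antagonist activity at melanin-concentrating hormone receptor 1 (Homo sapiens), read by GTPgammaS binding, with a stated time of 45 min; a lower number here means a less potent compound, a higher number a more potent compound, by a factor of ten per unit of this negative logarithm. Compound 3 reaches only a limit of the assay, not a number. The step of a number at least 0.34 log units lower from compound 2 to compound 3 (beyond the scatter) rests on the limit of < 5 in this assay, at which 1 of the 3 values shown sits, and is therefore known only as a bound. Compound 4 `COc1ccccc1-c1ccc(CN(CC(=O)C(C)(C)O)C(=O)NC2CCN(Cc3ccc(C)cc3)CC2)cc1` differs from compound 3 by 2-methoxyphenyl in place of 4-methoxyphenyl on an aromatic carbon. Among the compounds with values here, no measured step covers this change on its own; compound 1 carries the same 2-methoxyphenyl, though with a different group on the urea nitrogen, and in this assay compound 1 gives 6.19. Compound 3 sits at a limit, so the direction is the firmer part of any expectation. Compound 4 is expected to gain, with an estimated step of a number at least 0.40 log units higher from compound 3 to compound 4 (beyond the scatter). The estimate for compound 4 is 5.4, expected between 4.7 and 6.1.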

Compound 4, negative logarithm of the antagonist equilibrium constant: 5.43
The estimate for compound 4 lay 0.03 log units below the measured number, within the range that was stated.
By their numbers in this assay, from the lowest: compounds 2 and 4 (each within the scatter of the next); then compound 1. At a limit, below all of these: compound 3.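

In this assay the place of the methoxy matters when the ((1-hydroxy-1-methylethyl)carbonyl)methyl group sits on the urea nitrogen: 2-methoxyphenyl in place of 4-methoxyphenyl gives a number at least 0.43 log units higher from compound 3 to compound 4 (beyond the scatter) on this core. Compound 3 stands at a limit, so this step is only a bound: the limit of < 5 in this assay, at which 1 of the 4 values shown sits. Exchanging 4-fluorophenyl for 2-methoxyphenyl gives a number 0.09 log units higher from compound 2 to compound 4 (within the scatter) in this series, while adding that group to the urea nitrogen gives a number 0.76 log units lower from compound 1 to compound 4 (beyond the scatter) with 2-methoxyphenyl in place.

As far as these compounds go, whether an amine or a carboxylic acid in place of the methoxy would hold this number remains open, as does whether a shorter chain on that nitrogen would narrow the loss.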